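This account rests on a few compounds, and the source may have more. Where it says the series, first, only, none or still open, it means among the compounds named here.

Measured compounds:
Compound 1, `COc1ccc2c(c1)c(C1CC(c3ccccc3)=NN1C(=O)c1ccc(OC)nc1)cn2C`: in a functional assay on HeLa cells (Homo sapiens) for inhibition, read by MTT assay, with a stated time of 48 h (on this read-out higher numbers stand for weaker inhibition of growth and lower numbers for stronger inhibition of growth), compound 1 gives 1100 nM.
Compound 2, `COc1ccc2c(c1)c(C1CC(c3cc(OC)c(OC)c(OC)c3)=NN1C(=O)c1ccc(OC)nc1)cn2C`: in this assay compound 2 gives > 10000 nM, which is a limit of the assay and not a number.

Compound 2 therefore stands at the weak end of what has been measured here, at the limit of > 10000 nM in this assay, at which 1 of the 2 values shown sits, so only a range, not a point, is known for it. Among the measured compounds shown here, the single measured step is an at least 9.0-fold higher number from compound 1 to compound 2 (0.95 log units; beyond the scatter): the 3,4,5-trimethoxyphenyl group went with the weaker growth inhibition.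

Compound 3, `COc1cccc(C2=NN(C(=O)c3ccc(OC)nc3)C(c3cn(C)c4ccc(OC)cc34)C2)c1`, has not yet been measured. It differs from compound 2 by 3-methoxyphenyl in place of 3,4,5-trimethoxyphenyl on a carbon with a double bond to nitrogen. Two of the three methoxy groups are thus taken away again, leaving a ring that sits between the phenyl of compound 1 and the 3,4,5-trimethoxyphenyl of compound 2. For the measured compounds named here, the one measured step points toward stronger inhibition when methoxy groups are removed from this ring, so compound 3 is expected to show a lower number than compound 2 in this assay, with an estimated step of an at least 2.8-fold lower number from compound 2 to compound 3 (0.45 log units; beyond the scatter). The estimate for compound 3 is 3500 nM, expected to fall between 1200 nM and 10000 nM.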

Compound 3, concentration for 50% growth inhibition: 340 nM
Beside the measured number, compound 3's estimate is 10-fold (1.01 log units) above it; the whole stated range lies above it.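

In this assay, the ring on the carbon with a double bond to nitrogen does not follow a simple rule in which fewer methoxy groups give stronger inhibition. Replacing 3,4,5-trimethoxyphenyl with 3-methoxyphenyl gives an at least 29-fold lower number from compound 2 to compound 3 (1.46 log units; beyond the scatter), yet the ring with no methoxy group does not give the strongest inhibition, as adding a single methoxy group gives a 3.2-fold lower number from compound 1 to compound 3 (0.51 log units; beyond the scatter). This position therefore accepts one methoxy group, and among these three compounds the weak result goes with the full 3,4,5-trimethoxyphenyl group rather than with methoxy as such, although the first step has no known upper end since the value of compound 2 is a limit of the assay and not a number: the limit of > 10000 nM in this assay, at which 1 of the 3 values shown sits.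

The compounds shown remove two methoxy groups together, so it stays open whether one of them alone accounts for the loss or whether both are needed. As far as these compounds go, it also stays open whether the gain seen with 3-methoxyphenyl is particular to methoxy or would also appear with another group on that ring, such as a hydroxyl, a chlorine atom or an amine.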